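A bromophenyl replaces the dichlorobenzyl of compound 2

The compounds below may be only part of what the source reports. "The series", "measured", "known", "first", "only" and "open" are said of these compounds alone.

Measured so far in a functional assay on PC-3 cells (Homo sapiens) for cytotoxicity, read by cell counting, with a stated time of 48 h; a higher number here means a weaker inhibitor, a lower number a stronger inhibitor:
- Compound 1 `Clc1ccc(-n2cc(COc3cccc4cnc(Nc5cccc(Cl)c5)nc34)nn2)cc1`: > 25000 nM, a limit of the assay
- Compound 2 `Clc1cccc(Nc2ncc3cccc(OCc4cn(Cc5c(Cl)cccc5Cl)nn4)c3n2)c1`: 7000 nM

For the measured compounds named here, compound 2 reads 7000 nM, the only actual number in this small set. Compound 1 has reached only a limit, > 25000 nM. Going by the values given here, the single measured step is an at least 3.5-fold lower number from compound 1 to compound 2 (0.55 log units; beyond the scatter), which lies beyond the scatter and came with 2,6-dichlorobenzyl in place of 4-chlorophenyl on an aromatic nitrogen. That step is a bound and not a full size, since compound 1 stands at the limit of > 25000 nM in this assay, at which 1 of the 2 values shown sits.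

Compound 3 `Clc1cccc(Nc2ncc3cccc(OCc4cn(-c5ccc(Br)cc5)nn4)c3n2)c1` carries 4-bromophenyl in place of 2,6-dichlorobenzyl on an aromatic nitrogen. The change leaves compound 2 for a halogen-bearing phenyl group again, so an at least 3.5-fold lower number from compound 1 to compound 2 (0.55 log units; beyond the scatter) is the step that bears on it, read in reverse. On that reading, the expected result is a 3.1-fold higher number from compound 2 to compound 3 (0.50 log units; beyond the scatter), a move to a higher number in this assay of about the same size. Compound 3 is estimated at 22000 nM, with an expected range from 10000 nM to 50000 nM.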

Compound 3, half-maximal inhibitory concentration: 18000 nM
Estimate against measurement, compound 3: 1.2-fold (0.09 log units) above, and the stated range covers the measured number.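

In this assay, the position on the aromatic nitrogen now shows the same direction from a second side: leaving 2,6-dichlorobenzyl for 4-bromophenyl gives a 2.6-fold higher number from compound 2 to compound 3 (0.41 log units; beyond the scatter), so among these three, compound 2, the only benzyl compound, keeps the lowest number. The change within the phenyl series, bromo in place of chloro on an aromatic carbon, gives an at least 1.3-fold lower number from compound 1 to compound 3 (0.14 log units; that floor lies within the scatter), and that floor does not show that the two halogens differ. Compound 1 reads only as a limit of the assay, so this step has no full size: the limit of > 25000 nM in this assay, at which 1 of the 3 values shown sits.

Going by these compounds, whether the lower number of compound 2 goes with its benzyl link or with its two chloro groups stays open, as the two change together here, and a plain benzyl or a 4-bromobenzyl group on the same nitrogen would separate them. On these data alone, how a phenyl group bearing an amine or a carboxylic acid in place of the halogen would read also remains open.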